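Benzoyl in place of 4-fluorophenyl: an expected step

This account rests on a few compounds, and the source may have more. Where it says the series, first, only, none or still open, it means among the compounds named here.

In a functional assay on HepG2 cells (Homo sapiens) for inhibition, read by MTT assay, with a stated time of 48 h (a higher number here means a weaker inhibitor, a lower number a stronger inhibitor), compound 1 `COc1ccc(-n2c(SCc3ccccc3)nnc2-c2cc(OC)c(OC)c(OC)c2)cc1` gives only a limit, > 60000 nM. Compound 2 `COc1ccc(-n2c(SCc3ccc(C)cc3)nnc2-c2cc(OC)c(OC)c(OC)c2)cc1` gives 31600 nM, and compound 3 `COc1ccc(-n2c(SCc3ccc(F)cc3)nnc2-c2cc(OC)c(OC)c(OC)c2)cc1` gives 35000 nM, so these two stand within the scatter of each other. Compound 4 `COc1ccc(-n2c(SCC(=O)c3ccccc3)nnc2-c2cc(OC)c(OC)c(OC)c2)cc1` differs from compound 3 by benzoyl in place of 4-fluorophenyl on a saturated chain carbon bound to a sulfur, which places benzoyl in place of 4-fluorophenyl on a saturated chain carbon bound to a sulfur. Only ring substituent steps have been measured: an at least 1.8-fold lower number from compound 1 to compound 2 (0.27 log units; that floor lies within the scatter), an at least 1.7-fold lower number from compound 1 to compound 3 (0.23 log units; that floor lies within the scatter) and a 1.1-fold higher number from compound 2 to compound 3 (0.04 log units; within the scatter). All three stay within the scatter, and none alters the chain, so they support no expected direction. The expected result is a 1.2-fold lower number from compound 3 to compound 4 (0.07 log units; within the scatter), a change no larger than the scatter. For compound 4 the estimated value is 30000 nM, with an expected range from 10000 nM to 60000 nM.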

Compound 4, half-maximal inhibitory concentration: 16200 nM
Compound 4: the middle estimate sits 1.9-fold (0.27 log units) above what was measured; measured number inside the range.
By their numbers in this assay, from the lowest: compounds 4, 2 and 3 (each within the scatter of the next, the first and the last beyond it). At a limit, above all of these: compound 1.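

In this assay, for the compounds shown here, replacing the group on the saturated chain carbon bound to a sulfur gives what no ring substituent step gave, a change past the scatter: a 2.2-fold lower number from compound 3 to compound 4 (0.33 log units; beyond the scatter). With 4-methylphenyl leaving instead, the same kind of exchange gives a 2.0-fold lower number from compound 2 to compound 4 (0.29 log units; within the scatter), so the drop does not hold up in every comparison. With phenyl leaving, the step is an at least 3.7-fold lower number from compound 1 to compound 4 (0.56 log units; beyond the scatter), only a floor, as compound 1 gives just a limit: the limit of > 60000 nM in this assay, at which 1 of the 4 values shown sits.

From the compounds shown here alone, what remains open is whether the drop depends on the carbonyl itself. Going by these compounds, it is also open how an amine, a carboxylic acid or a longer chain would read at this place.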